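The source may report more compounds than this note shows. Statements on the series, on what has been measured and on what is new or still open speak of the compounds shown alone.

Measured compounds:
Compound 1, `N/C(=N\NC(=S)N1CCCCCC1)c1ccccn1`: 36.6%
Compound 2, `Cc1ccnc(/C(N)=N/NC(=S)N2CCN(c3ccccn3)CC2)c1`: 42.5%
Compound 3, `Cc1cccc(/C(N)=N/NC(=S)N2CCCCCC2)n1`: 63.6%

The three measured compounds were tested in a functional assay on HeLa cells (Homo sapiens) for cytotoxicity, read by MTT assay, with a stated time of 72 h, tested at 3 uM; on this read-out lower numbers stand for less inhibition of growth and higher numbers for more inhibition of growth at the one concentration tested. Compound 3 gives 63.6% there. Compound 1 differs from it by hydrogen in place of methyl on an aromatic carbon, and the step is a number 27 percentage points lower from compound 3 to compound 1 (beyond the scatter). Compound 2 gives 42.5% in this assay; the difference between its core and that of compound 3 is not broken down here, and the two values show compound 3 higher, beyond the scatter. Compound 2 and compound 1 lie within the scatter of each other.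

Compound 4, `N/C(=N\NC(=S)N1CCN(c2ccccn2)CC1)c1ccccn1`, is not yet measured. It differs from compound 2 by hydrogen in place of methyl on an aromatic carbon. This is the same kind of change as that from compound 3 to compound 1, but the place differs: there the methyl sat next to the ring nitrogen, here it sits opposite the ring nitrogen. Because of a number 27 percentage points lower from compound 3 to compound 1 (beyond the scatter) the expected step is a drop, yet the changed place makes its size uncertain, so a smaller step of a number 12.5 percentage points lower from compound 2 to compound 4 (beyond the scatter) is expected. Compound 4 is estimated to give 30% in this assay, between 15% and 45%.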

Compound 4, percent growth inhibition at one concentration: 24.4%
For compound 4 the middle estimate is 5.6 percentage points above the measured one; the measured number falls inside the stated range.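

In this assay, hydrogen in place of methyl, the change 4-methylpyridin-2-yl to pyridin-2-yl, gives a number 18.1 percentage points lower from compound 2 to compound 4 (beyond the scatter). The drop appears on both cores, and the two steps do not differ in size: the same change on two cores in this assay, a number 27 percentage points lower (beyond the scatter) from compound 3 to compound 1 and a number 18.1 percentage points lower (beyond the scatter) from compound 2 to compound 4, 8.9 percentage points apart, within the scatter of two such steps In these two pairs, hydrogen in place of methyl goes with less inhibition of growth even though the methyl sits at a different place on the ring in each pair, but two pairs do not show that the step would carry over to other cores or other ring places, and they do not explain why it occurs.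

The compounds shown leave open whether a larger or different group at these ring places, such as ethyl, methoxy or chlorine, would go with more inhibition of growth than methyl does. Going by these compounds, whether the step holds at other concentrations or in other cell lines also remains open.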